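Compound 2 to compound 3: plasma half-life

The source may hold more compounds than are shown below. What is called first, only, known or untested is meant among the compounds shown, and "the series" means these compounds.

- Compound 1 (`CCC/N=C1\S/C(=C\c2ccc(C(=O)O)cc2)C(=O)N1c1ccccc1O`) gives > 3 h as a limit
- Compound 2 (`CCC/N=C1\S/C(=C\c2ccc(C(=O)NCC(=O)N(C)C)cc2)C(=O)N1c1ccccc1O`) gives > 3 h as a limit

In an ADME assay on a cell-free system (plasma, Homo sapiens) for metabolic stability, at 37 degrees C (a higher number here means that the compound lasts longer, a lower number that the compound disappears faster), compound 2 stands at > 3 h as a limit, not a number. Both measured compounds share this limit (the limit of > 3 h in this assay, at which 2 of the 2 values shown sit). For the measured compounds named here, the only measured step (a step that the two limits leave unreadable from compound 1 to compound 2) offers no size to carry forward.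

Compound 3 (`CCC/N=C1\S/C(=C\c2ccc(C(=O)OCCCO)cc2)C(=O)N1c1ccccc1O`) has 3-hydroxypropoxy in place of ((dimethylcarbamoyl)methyl)amino on a carbonyl carbon. Neither measured compound carries this group, so the estimate is weakly grounded. A modest shortening of the half-life is expected (an at least 1.5-fold lower number from compound 2 to compound 3 (0.17 log units; that floor lies within the scatter)) in this assay here. Compound 3 is estimated at 2 h with an expected range from 0.5 h to 5 h in this work.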

Compound 3, half-life: > 3 h
Compound 3: only a limit was reported; the forecaster's own chance of this, stated with the estimate: 40%; at least 1.5-fold (0.17 log units) between middle value and limit.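

For the compounds shown here, compound 3 gives > 3 h, a limit and not a number, so no step among compound 1, compound 2 and compound 3 can be read. From the compounds shown here alone, the actual half-lives of all three compounds remain open.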